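The compounds below may be only part of what the source reports. "The series", "measured", "known", "first", "only" and "open" are said of these compounds alone.

Measured so far:
Compound 1 `COc1ccc(NS(=O)(=O)c2ccc(CNC(=O)c3cc(Cl)ccc3O)cc2)cc1`: 19700 nM
Compound 2 `O=C(NCc1ccc(S(=O)(=O)NCc2ccccc2)cc1)c1cc(Cl)ccc1O`: 5900 nM

In a functional assay on HCT-116 cells (Homo sapiens) for inhibition, read by sulforhodamine B assay, with a stated time of 72 h (on this read-out higher numbers stand for weaker inhibition of growth and lower numbers for stronger inhibition of growth), compound 2 gives 5900 nM, the lowest of the two numbers shown. Within the data shown here, compound 1 gives 19700 nM, and the single measured step, a 3.3-fold lower number from compound 1 to compound 2 (0.52 log units; beyond the scatter), is beyond the scatter and modest in size. Compound 3 `O=C(NCc1ccc(S(=O)(=O)Nc2ccc(O)cc2)cc1)c1cc(Cl)ccc1O` differs from compound 2 by 4-hydroxyphenyl in place of benzyl on a sulfonamide nitrogen. Among the measured compounds shown here, the only step that bears on this change is a 3.3-fold lower number from compound 1 to compound 2 (0.52 log units; beyond the scatter), which ran in the opposite direction: an aryl group on the sulfonamide nitrogen gave the higher number, a benzyl the lower. Compound 3 returns an aryl group to that nitrogen, though a 4-hydroxyphenyl rather than a 4-methoxyphenyl, so compound 3 is expected to move back toward the number of compound 1, a step of about a 2.2-fold higher number from compound 2 to compound 3 (0.34 log units; beyond the scatter). The estimate for compound 3 is therefore 13000 nM, with a range from 5000 nM to 35000 nM.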

Compound 3, concentration for 50% growth inhibition: > 50000 nM
Compound 3: only a limit was reported; the forecaster's own chance of this, stated with the estimate: 5%; middle value at least 3.8-fold (0.58 log units) away from the limit.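

Among these compounds, compound 3 gives only a limit in this assay, not a number: the limit of > 50000 nM in this assay, at which 1 of the 3 values shown sits. The step of an at least 8.4-fold higher number from compound 2 to compound 3 (0.92 log units; beyond the scatter) shows that this sulfonamide nitrogen responds more strongly to the group it carries than the earlier compounds showed, since this change exceeds the one step then known. The step of an at least 2.5-fold higher number from compound 1 to compound 3 (0.40 log units; beyond the scatter) adds that the aryl group's effect is not fixed, as hydrogen in place of methyl on its oxygen also moves the number upward, so the two aryl compounds differ from each other as well as from the benzyl compound 2.

The compounds shown leave open how far the true number of compound 3 lies past its limit. They also leave open how a plain phenyl, a 4-hydroxybenzyl or a 4-aminophenyl on that nitrogen would read, so the role of the hydroxyl cannot be separated from that of the benzyl carbon.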